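The compounds below may be only part of what the source reports. "The series", "measured", "known", "first", "only" and "open" are said of these compounds alone.

Compounds measured in a functional assay on Vero cells (Chlorocebus sabaeus); a higher number here means a weaker inhibitor, a lower number a stronger inhibitor:
compound 1 `OC[C@H]1C=C(F)[C@@H](n2cnc3c(O)ncnc32)S1` – > 100000 nM (a limit of this assay)
compound 2 `Nc1ncnc2c1ncn2[C@H]1S[C@@H](CO)C=C1F` – > 100000 nM (a limit of this assay)
compound 3 `OC[C@H]1C=C(F)[C@@H](n2cnc3c(O)nc(F)nc32)S1` – 66100 nM

Within the data shown here, compound 3 holds the only number in this assay; the other two values are limits. Compound 1 sits at the limit of > 100000 nM in this assay, at which 2 of the 3 values shown sit. Compound 2 sits at the same limit.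

Compound 4 `Nc1nc(O)c2ncn([C@H]3S[C@@H](CO)C=C3F)c2n1` differs from compound 3 by amino in place of fluoro on an aromatic carbon. Among the measured compounds shown here, two steps bear on this. Fluoro entering gave an at least 1.5-fold lower number from compound 1 to compound 3 (0.17 log units; that floor lies within the scatter), a floor inside the scatter, so its removal is expected to cost little or nothing readable. Amino in place of hydroxy gave a step that the two limits leave unreadable from compound 1 to compound 2, which the limits leave unreadable. Compound 4 is therefore expected to sit near compound 3 or back at the limit, the step of a 1.5-fold higher number from compound 3 to compound 4 (0.18 log units; within the scatter) being within the scatter or a modest loss. Compound 4 is estimated at 100000 nM, between 30000 nM and 300000 nM.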

Compound 4, half-maximal inhibitory concentration: 66400 nM
Compound 4: the middle estimate sits 1.5-fold (0.18 log units) above what was measured, and the stated range covers the measured number.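

In this assay, amino and fluoro on this aromatic carbon between two ring nitrogen atoms cannot be told apart: a 1.0-fold higher number from compound 3 to compound 4 (0.00 log units; within the scatter). Amino in place of hydrogen gives an at least 1.5-fold lower number from compound 1 to compound 4 (0.17 log units; that floor lies within the scatter), a floor of the same size as the one for fluoro, an at least 1.5-fold lower number from compound 1 to compound 3 (0.17 log units; that floor lies within the scatter). Compound 1 stands at a limit, > 100000 nM, so neither floor shows a true size, and the position has so far tolerated a donor-bearing amino as readily as fluoro.

From the compounds shown here alone, whether chloro, methoxy or methylamino on this carbon would give a step beyond the scatter stays open.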